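Benzyl(ethyl)carbamoyl Replaces Phenoxy: Cytotoxicity Outlook

The source may report more compounds than this note shows. Statements on the series, on what has been measured and on what is new or still open speak of the compounds shown alone.

Of the compounds shown here, two that share one core have been tested in an ADME assay (Homo sapiens) for cytotoxicity; on this read-out higher numbers stand for lower toxicity in this test and lower numbers for higher toxicity in this test. Compound 1 `CC(=O)N1CCC(C(=O)N(CCCN2CCC(CNC(=O)c3ccsc3)CC2)c2ccc(C)c(Cl)c2)CC1` carries a (((thiophen-3-yl)carbonyl)amino)methyl group on a saturated ring carbon. In this assay compound 1 reaches only the limit of the test, at > 51900 nM. Compound 2 `CC(=O)N1CCC(C(=O)N(CCCN2CCC(Oc3ccccc3)CC2)c2ccc(C)c(Cl)c2)CC1` has a phenoxy group in that place. In this assay compound 2 likewise reaches only a limit, at > 56600 nM. Going by the values given here, compound 2 therefore stands at a limit, as does the one other value shown, and the step that the two limits leave unreadable from compound 1 to compound 2 cannot be read, since the limit of > 51900 nM in this assay, at which 1 of the 2 values shown sits, and the limit of > 56600 nM in this assay, at which 1 of the 2 values shown sits, give no number on either side.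

Compound 3 `CCN(Cc1ccccc1)C(=O)C1CCN(CCCN(C(=O)C2CCN(C(C)=O)CC2)c2ccc(C)c(Cl)c2)CC1` differs from compound 2 by benzyl(ethyl)carbamoyl in place of phenoxy on a saturated ring carbon. Among the compounds with values here, no measured step bears on this change, as the only step known is unreadable. Because both compounds 1 and 2 sit at the limit of > 51900 nM in this assay, at which 1 of the 2 values shown sits, and (the limit of > 56600 nM in this assay, at which 1 of the 2 values shown sits), the expectation for compound 3 is no step beyond the scatter, an at least 1.1-fold lower number from compound 2 to compound 3 (0.05 log units; that floor lies within the scatter). Compound 3 is thus estimated at 50000 nM, within the range from 15000 nM to 100000 nM, most likely again as a limit.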

Compound 3, half-maximal cytotoxic concentration: 83.9 nM
The estimate for compound 3 lay 600-fold (2.78 log units) above the measured number, outside the stated range (below it).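

In this assay, the position on the saturated ring carbon, three ring bonds from the ring nitrogen, proves far from indifferent: the step between the two earlier compounds cannot be read, yet benzyl(ethyl)carbamoyl in this place gives an at least 670-fold lower number from compound 2 to compound 3 (2.82 log units; beyond the scatter), and the comparison with the (((thiophen-3-yl)carbonyl)amino)methyl group gives an at least 610-fold lower number from compound 1 to compound 3 (2.79 log units; beyond the scatter). Both steps lie beyond the scatter, so among the three compounds shown, compound 3 has the highest toxicity in this test, while neither phenoxy nor the (((thiophen-3-yl)carbonyl)amino)methyl group yields a measured number. The step from compound 2 gives only a floor, since the value of compound 2 is a limit of the test: the limit of > 56600 nM in this assay, at which 1 of the 3 values shown sits.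

The compounds shown leave open which part of benzyl(ethyl)carbamoyl goes with the lower number, and a dimethylcarbamoyl group or a benzyl group set directly on the ring carbon would help to separate the benzyl, the ethyl and the carbonyl. Going by these compounds, it also remains open whether the same change would give a similar step on a different core, or how far the true values of compound 1 and compound 2 lie beyond their limits.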